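The compounds below may be only part of what the source reports. "The series", "measured", "known", "first", "only" and "open" are said of these compounds alone.

Measured in an ADME assay on Vero cells (Chlorocebus sabaeus) for cytotoxicity, read by MTT assay; a higher number here means a weaker inhibitor, a lower number a stronger inhibitor:
- compound 1 `CCCCCC(=O)OCC(C)(C)CC1=C(O)C(=O)c2ccccc2C1=O`: 169000 nM
- compound 2 `CCCCCCCCCCCCCC(=O)OCC(C)(C)CC1=C(O)C(=O)c2ccccc2C1=O`: 58400 nM

Of these two, compound 2 has the lower number, at 58400 nM. Compound 3 `CCCCCCCCCCCCCCCC(=O)OCC(C)(C)CC1=C(O)C(=O)c2ccccc2C1=O` departs from compound 2 by a single change: ethyl in place of hydrogen on a saturated chain carbon, ten or more bonds along the chain from a carbonyl carbon. Going by the values given here, only one measured step bears on this change. It is the modest 2.9-fold lower number from compound 1 to compound 2 (0.46 log units; beyond the scatter), which came with octyl in place of hydrogen on a saturated chain carbon of the same ester chain. Ethyl is a much smaller addition than octyl, and this one step is the only guide, so a much smaller move in the same direction is expected in this assay, probably not beyond the scatter. The estimate amounts to an expected 1.3-fold lower number from compound 2 to compound 3 (0.10 log units; within the scatter). For compound 3 the expected value is 46000 nM, with an estimated range of 23000 nM to 92000 nM.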

Compound 3, half-maximal inhibitory concentration: 4410 nM
Estimate against measurement, compound 3: 10-fold (1.02 log units) above; the whole stated range lies above it.
By their numbers in this assay, from the lowest: compound 3; then compound 2; then compound 1.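

In this assay, adding ethyl at this far end of the ester chain gave a 13-fold lower number from compound 2 to compound 3 (1.12 log units; beyond the scatter) as a large step, while the much larger octyl addition gave only a 2.9-fold lower number from compound 1 to compound 2 (0.46 log units; beyond the scatter) as a modest one. The number therefore does not fall evenly with chain length across these three compounds, and the last addition carries most of the overall a 38-fold lower number from compound 1 to compound 3 (1.58 log units; beyond the scatter) along the series. No measurement shown here accounts for this sharp drop.

Going by these compounds, whether a longer chain would lower the number further, hold it or raise it again remains open, so it is unclear if compound 3 lies near a limit of this trend. Also open, on these data alone, is how this assay would read with an amine or a carboxylic acid at the end of the chain in place of the last carbons.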